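The source may report more compounds than this note shows. Statements on the series, on what has been measured and on what is new or still open speak of the compounds shown alone.

- Compound 1 `Cc1cc(C)c(CN2CCc3c(Cl)cc([C@H](CO)[C@H]4CCOC4)c(Cl)c3C2=O)c(=O)[nH]1`: 570000 nM
- Compound 2 `COC(c1cc(Cl)c2c(c1Cl)C(=O)N(Cc1c(C)cc(C)[nH]c1=O)CC2)C1CCS(=O)(=O)CC1`: 373000 nM; 415000 nM (2 entries)

For the measured compounds named here, in a physicochemical assay for solubility, measured as kinetic solubility (on this read-out lower numbers stand for lower solubility and higher numbers for higher solubility), compound 1 gives 570000 nM, its only number, and one further entry for it carries no single number. The values of compound 1 and compound 2 lie within the usual scatter of each other. Compound 3 `Cc1cc(C)c(CN2CCc3c(Cl)cc([C@@H](CO)[C@@H]4CCOC4)c(Cl)c3C2=O)c(=O)[nH]1` is the mirror image of compound 1: the two compounds have the same atoms and bonds and differ only in configuration as drawn: 2 of 2 stereo elements differ (all stereocentres are inverted: mirror images); a stereocentre at a saturated chain carbon is drawn R in compound 1 and S in compound 3; a stereocentre at a saturated ring carbon is drawn R in compound 1 and S in compound 3. Going by the values given here, no measured step bears on this inversion of all stereocentres, so no step beyond the scatter is expected in this assay, in either direction. The expected 1.1-fold lower number from compound 1 to compound 3 (0.06 log units; within the scatter) stays within the scatter. Compound 3 is estimated at 500000 nM, with an expected range of 280000 nM to 800000 nM.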

Compound 3, solubility: 537000 nM
For compound 3 the middle estimate is 1.1-fold (0.03 log units) below the measured one; the range from low to high includes it.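

In this assay, the first step read at this place is a 1.1-fold lower number from compound 1 to compound 3 (0.03 log units; within the scatter), so this mirror-image pair does not separate on this read-out. The step is of the same order as the spread between repeat entries of one compound: the several entries of compound 2 in this assay, 373000 nM; 415000 nM (2 entries). Configuration as drawn, taken alone, therefore moves the number only within the scatter here: the fact that compounds 1 and 3 differ only in the configuration as drawn. The compounds shown leave open whether inverting just one of the two stereocentres would read the same. They also leave open how an amine or a carboxylic acid in place of the hydroxyl would read.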